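The compounds below may be only part of what the source reports. "The series", "measured", "known", "first", "only" and "open" are said of these compounds alone.

Compound 1, `CN(C)CCCNc1nc2cc([N+](=O)[O-])ccc2nc1NCc1ccc(C(F)(F)F)cc1`, gives 5.66 ug/mL in an ADME assay on HEK293 cells (Homo sapiens) for cytotoxicity, read by MTT assay, with a stated time of 24 h; on this read-out higher numbers stand for weaker inhibition and lower numbers for stronger inhibition. Among the compounds with values here, compound 2, `CN1CCN(CCCNc2nc3cc([N+](=O)[O-])ccc3nc2NCc2ccc(C(F)(F)F)cc2)CC1`, gives 9.53 ug/mL, and the step of a 1.7-fold higher number from compound 1 to compound 2 (0.23 log units; within the scatter), so compound 1 sits within the scatter of the only other compound with a number. Compound 3, `O=[N+]([O-])c1ccc2nc(NCc3ccc(C(F)(F)F)cc3)c(N3CCCCC3)nc2c1`, is reported only as a limit, > 200 ug/mL. The steps of an at least 35-fold higher number from compound 1 to compound 3 (1.54 log units; beyond the scatter) and an at least 20-fold higher number from compound 2 to compound 3 (1.32 log units; beyond the scatter) are the large ones seen, and both run to the limit of > 200 ug/mL in this assay, at which 1 of the 3 values shown sits. Compound 4, `CN(C)CCCNc1nc2cc([N+](=O)[O-])ccc2nc1NCc1ccc(Cl)cc1`, differs from compound 1 by chloro in place of trifluoromethyl on an aromatic carbon. Within the data shown here, no measured step touches this part of the molecule; all three steps alter the amine side of the shared core. No step beyond the scatter is therefore expected in this assay, and compound 4 is estimated at 5.7 ug/mL, between 2.5 ug/mL and 13 ug/mL, a step of a 1.0-fold higher number from compound 1 to compound 4 (0.00 log units; within the scatter).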

Compound 4, half-maximal inhibitory concentration: 10.7 ug/mL
Compound 4: the middle estimate sits 1.9-fold (0.27 log units) below what was measured; low and high end bracket the measured number.
By their numbers in this assay, from the lowest: compounds 1, 2 and 4 (each within the scatter of the next). At a limit, above all of these: compound 3.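

Within the data shown here, this is the first measured change at this aromatic carbon rather than on the amine side of the shared core: in this assay, putting chloro in place of trifluoromethyl gives a 1.9-fold higher number from compound 1 to compound 4 (0.28 log units; within the scatter), so this swap stays inside the scatter. The large steps seen so far therefore remain those on the amine side. Nothing measured here gives a reason for this step. As far as these compounds go, it remains open whether other groups at this place, such as methoxy or a nitrile, would also stay within the scatter. From the compounds shown here alone, it also remains open whether chloro would behave alike on the 4-methylpiperazin-1-yl chain of compound 2.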